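Swapping the Amide Linker for a Sulfonamide on a Shared Core

The source may hold more compounds than are shown below. What is called first, only, known or untested is meant among the compounds shown, and "the series" means these compounds.

Compound 1 `Cc1ccc(C(=O)Nc2cccc(/C=C/C(=O)c3nc4ccccc4[nH]3)c2)cc1` and compound 2 `Cc1cc(C)cc(C(=O)Nc2cccc(/C=C/C(=O)c3nc4ccccc4[nH]3)c2)c1` share one core and differ only in the aryl group attached to the carbonyl carbon. In a functional assay on MCF7 cells (Homo sapiens) for antiproliferative activity, read by MTT assay, with a stated time of 48 h (on this read-out higher numbers stand for weaker inhibition and lower numbers for stronger inhibition), compound 1 gives 9690 nM, and compound 2 gives 24600 nM. That makes compound 2 the higher of the two numbers, the step being a 2.5-fold higher number from compound 1 to compound 2 (0.40 log units; beyond the scatter).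

Compound 3 `O=C(/C=C/c1cccc(NS(=O)(=O)c2ccccc2Cl)c1)c1nc2ccccc2[nH]1` changes a different element of the structure: (2-chlorophenyl)sulfonyl in place of (3,5-dimethylphenyl)carbonyl on a nitrogen on an aromatic ring. Among the measured compounds shown here, the only measured step concerns the methyl pattern on the ring bound to the carbonyl carbon, not the replacement of a carbonyl by a sulfonyl, so no measured step bears directly on this change and no direction can be read from the data. The step from compound 2 to compound 3 is therefore expected to be a 1.6-fold lower number from compound 2 to compound 3 (0.21 log units; within the scatter), with wide uncertainty. Compound 3 is estimated at 15000 nM in this assay, within a range from 3500 nM to 60000 nM.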

Compound 3, half-maximal inhibitory concentration: 4280 nM
The estimate for compound 3 lay 3.5-fold (0.54 log units) above the measured number, and the stated range covers the measured number.
By their numbers in this assay, from the lowest: compound 3; then compound 1; then compound 2.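

Among the compounds shown here, until now the only measured change at this place was the methyl pattern on the ring bound to the carbonyl, whereas putting (2-chlorophenyl)sulfonyl in place of (3,5-dimethylphenyl)carbonyl on the same nitrogen gives a 5.7-fold lower number from compound 2 to compound 3 (0.76 log units; beyond the scatter) and thus stronger inhibition. The same kind of swap made against the (4-methylphenyl)carbonyl group gives a 2.3-fold lower number from compound 1 to compound 3 (0.35 log units; beyond the scatter) and again favours the sulfonyl compound, so compound 3 has the lowest number of the three, and both steps lie beyond the scatter. Nothing available explains this gain.

On these data alone, the sulfonyl and the chlorine enter together, so their separate shares of the step remain open, and a (4-methylphenyl)sulfonyl group would be one way to separate them. As far as these compounds go, how an amine or a carboxylic acid on that ring would read also remains open.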